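Compound 2 Trades Its Amide Side for Isopentyloxy

The source may report more compounds than this note shows. Statements on the series, on what has been measured and on what is new or still open speak of the compounds shown alone.

In a functional assay on a cell-free system (Platelet, plasma, Homo sapiens) for inhibition, read by turbidimetry, with a stated time of 3 min (a higher number here means a weaker inhibitor, a lower number a stronger inhibitor), compound 1 (`COc1ccc(-n2nc(C(=O)Nc3ccncc3)cc2-c2ccc(Cl)cc2)nn1`) gives 110 nM and compound 2 (`COc1ccc(-n2nc(C(=O)Nc3ccc(Cl)cc3)cc2-c2ccc(Cl)cc2)nn1`) gives 610 nM as the higher of the two numbers. Compound 3 (`COc1ccc(-n2nc(C(=O)OCCC(C)C)cc2-c2ccc(Cl)cc2)nn1`) is unmeasured and differs from compound 2 by isopentyloxy in place of (4-chlorophenyl)amino on a carbonyl carbon with isopentyloxy in place of (4-chlorophenyl)amino on a carbonyl carbon. Going by the values given here, the only measured step, a 5.5-fold higher number from compound 1 to compound 2 (0.74 log units; beyond the scatter), swaps 4-chlorophenyl for pyridin-4-yl on an amide-type nitrogen, and no measured step removes that nitrogen. A similar modest move toward a weaker inhibitor is therefore expected, estimated as a 2.5-fold higher number from compound 2 to compound 3 (0.39 log units; beyond the scatter) in this assay here. For compound 3 the estimate is 1500 nM within an expected range of 300 nM to 7000 nM for now.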

Compound 3, half-maximal inhibitory concentration: 1330 nM
Compound 3: middle estimate off by 1.1-fold (0.05 log units), on the high side; the range from low to high includes it.
By their numbers in this assay, from the lowest: compound 1; then compound 2; then compound 3.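

In this assay the carbonyl carbon keeps a measurable inhibitor without any amide-type nitrogen: isopentyloxy, with no ring and no hydrogen-bond donor, replaces (4-chlorophenyl)amino and gives a 2.2-fold higher number from compound 2 to compound 3 (0.34 log units; beyond the scatter) as a modest loss. Replacing (pyridin-4-yl)amino instead gives a 12-fold higher number from compound 1 to compound 3 (1.08 log units; beyond the scatter) as a large loss, which puts compound 3 highest of the three numbers. No evidence is available on what lies behind these steps. 

As far as these compounds go, it remains open whether an amide bearing an isopentyl chain would separate losing the nitrogen from losing the ring. From the compounds shown here alone, how a shorter chain on the oxygen or a carboxylic acid at this carbonyl carbon would read also stays unknown.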